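Swapping a Five-Membered Ring on a Shared Core

The source may hold more compounds than are shown below. What is called first, only, known or untested is meant among the compounds shown, and "the series" means these compounds.

Three compounds share one core and differ only in the five-membered aromatic ring attached to it. Compound 1 `OC[C@H]1OC(n2cnc3c(-c4cc[nH]c4)ncnc32)[C@H](O)[C@@H]1O` gives 1030 nM in a functional assay on CCRF-CEM cells (Homo sapiens) for inhibition; on this read-out lower numbers stand for stronger inhibition and higher numbers for weaker inhibition. Compound 2 `OC[C@H]1OC(n2cnc3c(-c4ccoc4)ncnc32)[C@H](O)[C@@H]1O` gives 1650 nM in this assay. Compound 3 `Cc1csc(-c2ncnc3c2ncn3C2O[C@H](CO)[C@@H](O)[C@H]2O)c1` gives 2900 nM in this assay, the highest number of the three; the step of a 2.8-fold higher number from compound 1 to compound 3 (0.45 log units; beyond the scatter) lies beyond the scatter, whereas a 1.8-fold higher number from compound 2 to compound 3 (0.24 log units; within the scatter) and a 1.6-fold higher number from compound 1 to compound 2 (0.20 log units; within the scatter) do not. Compound 4 `OC[C@H]1OC(n2cnc3c(-c4nccs4)ncnc32)[C@H](O)[C@@H]1O` has not yet been measured; it differs from compound 3 in one place: 1,3-thiazol-2-yl in place of 4-methylthiophen-2-yl on an aromatic carbon. Every measured step here exchanges one five-membered aromatic ring for another, and all of them are small, the largest being a 2.8-fold higher number from compound 1 to compound 3 (0.45 log units; beyond the scatter). A step of similar size is therefore expected for this exchange, and the number for compound 4 is expected to sit somewhat below that of compound 3, as a 1.6-fold lower number from compound 3 to compound 4 (0.21 log units; within the scatter). Compound 4 is estimated at 1800 nM, with a range from 700 nM to 4500 nM.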

Compound 4, half-maximal inhibitory concentration: 2730 nM
The estimate for compound 4 lay 1.5-fold (0.18 log units) below the measured number; measured number inside the range.
By their numbers in this assay, from the lowest: compounds 1, 2, 4 and 3 (each within the scatter of the next, the first and the last beyond it).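

The position tolerates a further ring change: 1,3-thiazol-2-yl, a five-membered aromatic ring with 2 hetero atoms, replaces 4-methylthiophen-2-yl, a ring with 1 hetero atom, and this assay shows a 1.1-fold lower number from compound 3 to compound 4 (0.03 log units; within the scatter) with no change that stands out from the scatter. Among the compounds shown here, the comparison with furan-3-yl, a 1.7-fold higher number from compound 2 to compound 4 (0.22 log units; within the scatter) and also within the scatter, fits this picture, while a 2.7-fold higher number from compound 1 to compound 4 (0.42 log units; beyond the scatter) lies beyond the scatter, so 1H-pyrrol-3-yl is the only ring here that compound 4 can be told apart from, as was already so for compound 3. Nothing shown here offers a reason for these numbers.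

On these data alone, all four groups are five-membered aromatic rings, so it stays open how this position responds to a different kind of group, such as an amine, a carboxylic acid or a six-membered phenyl ring. As far as these compounds go, it is also open whether any group here can move the number much further than these modest steps.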